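The source may hold more compounds than are shown below. What is called first, only, known or untested is meant among the compounds shown, and "the series" means these compounds.

In a functional assay on the whole organism (Tail, strain ICR) with Mus musculus as the target, in the tail flick test, with a stated time of 30 min, at a dose of 25 umol/kg by the oral route (on this read-out lower numbers stand for a weaker effect and higher numbers for a stronger effect at the one dose given), compound 2 `CC(C)C[C@H](NC(=O)CN(c1nc(Cl)nc2[nH]cnc12)C1CC1)C(=O)OCc1ccccc1` gives 33.9%, the highest of the two numbers; compound 1 `O=C(CN(c1nc(Cl)nc2[nH]cnc12)C1CC1)NCC(=O)OCc1ccccc1` gives 18.7%. Going by the values given here, the one measured step, a number 15.2 percentage points higher from compound 1 to compound 2 (beyond the scatter), is the only guide to the next change. Compound 3 `NC(=O)C[C@H](NC(=O)CN(c1nc(Cl)nc2[nH]cnc12)C1CC1)C(=O)OCc1ccccc1` differs from compound 2 by carbamoyl in place of isopropyl on a saturated chain carbon, two bonds along the chain from an amide-type nitrogen and a carbonyl carbon. Among the compounds with values here, the isobutyl that carried that gain is replaced, and no measured step shows what a carbamoyl does at this place, so part of the gain is expected to be given back, a number 11.9 percentage points lower from compound 2 to compound 3 (beyond the scatter). Compound 3 is therefore estimated at 22%, with a range from 8% to 38%.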

Compound 3, a percentage reported as activity, at one dose (the size of the read-out at that dose, not a potency): 24.4%
The estimate for compound 3 lay 2.4 percentage points below the measured number; the measured number falls inside the stated range.
By their numbers in this assay, from the lowest: compounds 1, 3 and 2 (each within the scatter of the next, the first and the last beyond it).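

In this assay, carbamoyl in place of isopropyl gives a number 9.5 percentage points lower from compound 2 to compound 3 (within the scatter), while carbamoylmethyl in place of hydrogen gives a number 5.7 percentage points higher from compound 1 to compound 3 (within the scatter). Compound 3 therefore cannot be told apart from either compound 2 or compound 1, although those two are separated from each other, so this group leaves open how much of the isobutyl gain remains. No available evidence bears on this result. Going by these compounds, whether a carboxylic acid, an amine or a longer chain at this place would stand clear of compound 2 remains open.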